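The source may report more compounds than this note shows. Statements on the series, on what has been measured and on what is new or still open speak of the compounds shown alone.

Compound 3 `CN1CCN(Cc2ccc(-c3ccc(CCC(=O)c4ncc(-c5cccc(C(=O)O)n5)o4)cc3)cc2)CC1` stands highest in an assay for inhibition of Fatty-acid amide hydrolase 1 (Rattus norvegicus) (on this read-out higher numbers stand for weaker inhibition and lower numbers for stronger inhibition), among the three compounds measured: in this assay compound 3 gives 1200 nM. The other two sit far lower. Compound 1 `CCOC(=O)c1cccc(-c2cnc(C(=O)CCc3ccc(-c4ccccc4)cc3)o2)n1` gives 3 nM in this assay, and compound 2 `NC(=O)c1ccc(-c2cnc(C(=O)CCc3ccc(-c4ccccc4)cc3)o2)nc1` gives 1.3 nM, so both lie well beyond the usual scatter away from compound 3. Compound 4 `O=C(O)c1cccc(-c2cnc(C(=O)CCc3ccc(-c4ccc(CN5CCCC5)cc4)cc3)o2)n1` has not yet been measured. It differs from compound 3 in one place: pyrrolidin-1-yl in place of 4-methylpiperazin-1-yl on a saturated chain carbon bound to an aromatic carbon. Among the measured compounds shown here, no measured pair shows the effect of such a change, so the expectation rests on the value of compound 3 alone. The step is expected to be small, a modest move toward a lower number that may not clear the usual scatter, the estimated step being a 1.5-fold lower number from compound 3 to compound 4 (0.18 log units; within the scatter). On that basis compound 4 is expected to give about 800 nM in this assay, with a range from 200 nM to 3000 nM.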

Compound 4, inhibition constant: 130 nM
Compound 4: middle estimate off by 6.2-fold (0.79 log units), on the high side; measured number below the stated range.
By their numbers in this assay, from the lowest: compound 2; then compound 1; then compound 4; then compound 3.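

Among the compounds shown here, at the saturated chain carbon bound to an aromatic carbon, the choice of ring matters in this assay: pyrrolidin-1-yl in place of 4-methylpiperazin-1-yl gives a 9.2-fold lower number from compound 3 to compound 4 (0.97 log units; beyond the scatter), the only single change that can be read in this set. The entering ring is a five-membered ring with one hetero atom and the leaving ring a six-membered ring with two, but one pair cannot show which of these differences, or the loss of the methyl group, carries the step. Nothing measured here accounts for the size of the step.

As far as these compounds go, it remains open whether a piperidin-1-yl, a morpholin-4-yl or an open-chain dimethylamino group on the same carbon would follow the same trend. From the compounds shown here alone, it also remains open whether the change would read the same with an ethyl ester in place of the carboxylic acid.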